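A few compounds are considered here, and "the series" means these few. Any claim that something is new, unique, unknown or untested is made for them only; others in the source may bear on it.

Measured in a functional assay on PC-3 cells (Homo sapiens) for cytotoxicity, read by colorimetric assay; a higher number here means a weaker inhibitor, a lower number a stronger inhibitor:
- compound 1 `Cc1ccc2c(c1)/C(=C1/Nc3ccccc3/C1=N\O)C(=O)N2Cc1ccc(/C=C/C(=O)NO)cc1`: 60 nM
- compound 2 `O=C(/C=C/c1ccc(CN2C(=O)/C(=C3\Nc4ccccc4\C3=N/O)c3cc(F)ccc32)cc1)NO`: 50 nM

Compound 2, at 50 nM, cannot be told apart from compound 1 in this assay. Compound 3 `O=C(/C=C/c1ccc(CN2C(=O)/C(=C3\Nc4ccccc4\C3=N/O)c3ccccc32)cc1)NO` has hydrogen in place of fluoro on an aromatic carbon. Among the measured compounds shown here, one measured step bears on this, as it changes the group on the same carbon: a 1.2-fold lower number from compound 1 to compound 2 (0.08 log units; within the scatter). For the measured compounds named here, with methyl and fluoro giving values this close, hydrogen is expected to make no difference beyond the scatter, though no measured compound yet shows hydrogen there. The expected step is a 1.1-fold higher number from compound 2 to compound 3 (0.04 log units; within the scatter). For compound 3 the estimated value is 55 nM, with an expected range of 25 nM to 120 nM.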

Compound 3, half-maximal inhibitory concentration: 50 nM
Beside the measured number, compound 3's estimate is 1.1-fold (0.04 log units) above it; measured number inside the range.
By their numbers in this assay, from the lowest: compounds 2, 3 and 1 (each within the scatter of the next).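

Replacing fluoro with hydrogen on this aromatic carbon in this assay gives no change at the digits printed from compound 2 to compound 3 (within the scatter) while replacing methyl with hydrogen gives a 1.2-fold lower number from compound 1 to compound 3 (0.08 log units; within the scatter) on the shared core. With hydrogen now measured, neither fluoro nor methyl stands apart from the unsubstituted compound 3 at this position. Nothing available explains this flat result. As far as these compounds go, whether an amine, a methoxy group or a carboxylic acid on this carbon would also stay within the scatter remains open.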